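The source may hold more compounds than are shown below. What is called first, only, known or untested is meant among the compounds shown, and "the series" means these compounds.

Compound 2 `COc1cccc(N2CCN(CCCn3cccc3C(C)=O)CC2)c1` has been measured in a functional assay on the whole organism (Abdomen, strain Swiss) for inhibition, with Mus musculus as the target, with stated times of 30 min, 10 min and 5 min, at a dose of 10 mg/kg by the oral route (on this read-out higher numbers stand for a stronger effect at the one dose given and lower numbers for a weaker effect), where compound 2 gives 0%. For the measured compounds named here, its only measured neighbour is compound 1 `CC(=O)c1cccn1CCCN1CCN(c2ccc(F)cc2)CC1`, and in this assay compound 1 gives 0%. The single step between the two, no change at the digits printed from compound 1 to compound 2 (within the scatter), which replaced 4-fluorophenyl with 3-methoxyphenyl on the amine nitrogen in a ring, thus moved nothing at the digits shown.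

Compound 3 `CC(=O)c1cccn1CCCN1CCN(c2ccc(C)cc2)CC1` has not yet been measured in this assay. It differs from compound 2 by 4-methylphenyl in place of 3-methoxyphenyl on an amine nitrogen in a ring. Going by the values given here, the only measured step that bears on this change is the one already described, no change at the digits printed from compound 1 to compound 2 (within the scatter). That step also exchanged the aryl group on the same ring nitrogen and stayed within the scatter. On that basis the account expects no step beyond the scatter for compound 3, that is an expected change of no change at the digits printed from compound 2 to compound 3 (within the scatter). Compound 3 is therefore estimated at 0% in this assay, with an expected range from 0% to 15%.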

Compound 3, a percentage reported as inhibition, in the whole organism at one dose (the size of the read-out at that dose, not a potency): 12%
Estimate against measurement, compound 3: 12 percentage points below; the range from low to high includes it.
By their numbers in this assay, from the lowest: compounds 1 and 2 (each within the scatter of the next); then compound 3.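

Exchanging 3-methoxyphenyl for 4-methylphenyl on the amine nitrogen in the ring gives a number 12 percentage points higher from compound 2 to compound 3 (beyond the scatter) in this assay, which shows that the read-out can respond to the aryl group at this position, something the earlier step among the aryl groups did not reveal. Methyl in place of fluoro on an aromatic carbon gives a number 12 percentage points higher from compound 1 to compound 3 (beyond the scatter), so a change in that one substituent, with the rest of the molecule held constant, is enough to separate compound 3 from compound 1, although the step is modest. The data shown offer no measured explanation for why the 4-methylphenyl group stands apart from the other two aryl groups.

The compounds shown leave open whether the read-out would rise further with an ethyl group or a trifluoromethyl group in place of the methyl, or whether a chloro group or a hydroxyl group would give a similar result. They also leave open whether the effect at this one oral dose would hold at other doses, so the step says nothing about potency.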